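The source may report more compounds than this note shows. Statements on the series, on what has been measured and on what is new or still open speak of the compounds shown alone.

Of the compounds shown here, two built on the same core have been measured in a functional assay on A-375 cells (Homo sapiens) for antiproliferative activity, read by MTT assay, with a stated time of 24 h, tested at 100 ug/mL; on this read-out higher numbers stand for a stronger effect at the one concentration tested and lower numbers for a weaker effect. Compound 1, `CCc1ccc2nc(C(=O)Nc3c(F)cc(-c4cccc(F)c4)cc3F)c(C)c(O)c2c1`, gives 47.3% in this assay. Compound 2, `Cc1ccc2nc(C(=O)Nc3c(F)cc(-c4cccc(F)c4)cc3F)c(C)c(C(=O)O)c2c1`, gives 37.3% in this assay, a number that lies within the usual scatter of the value for compound 1, so the two cannot be told apart on these data. Compound 3, `CCc1ccc2nc(C(=O)Nc3c(F)cc(-c4cccc(F)c4)cc3F)c(C)c(C(=O)O)c2c1`, has not yet been measured. It differs from compound 2 in one place: methyl in place of hydrogen on a saturated chain carbon bound to an aromatic carbon. For the measured compounds named here, no pair of measured compounds differs in exactly one place, so no measured step shows what this change does on its own. Compound 1 also carries the ethyl chain, and because its value of 47.3% in this assay sits within the scatter of compound 2, the change is expected to matter little. The step expected in this assay is a number 2.7 percentage points higher from compound 2 to compound 3 (within the scatter), in no direction beyond the scatter. Compound 3 is estimated to give 40% in this assay, with a likely range from 26% to 54%.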

Compound 3, a percentage reported as inhibition, at one concentration (the size of the read-out at that concentration, not a potency): 71.3%
Beside the measured number, compound 3's estimate is 31.3 percentage points below it, and the stated range ends below it.
By their numbers in this assay, from the lowest: compounds 2 and 1 (each within the scatter of the next); then compound 3.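

In this assay, a single added methyl on a saturated chain carbon bound to an aromatic carbon, which turns methyl into ethyl, gives a number 34 percentage points higher from compound 2 to compound 3 (beyond the scatter), so with the carboxy group present this position is far from indifferent. With the ethyl chain kept in place, carboxy in place of hydroxy on an aromatic carbon gives a number 24 percentage points higher from compound 1 to compound 3 (beyond the scatter), a change on its own that the two earlier compounds, differing in two places, could not show. No measurement shown explains either step.

The compounds shown leave open whether a longer chain such as propyl, or a branched one such as isopropyl, would raise the number further or lower it. They also leave open whether an amide in place of the carboxy group would keep the effect seen with the ethyl chain.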